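The compounds below may be only part of what the source reports. "The series", "measured", "known", "first", "only" and "open" are said of these compounds alone.

In a functional assay on MDA-MB-435 cells (Homo sapiens) for cytotoxicity, read by MTT assay, with a stated time of 72 h (on this read-out higher numbers stand for weaker inhibition and lower numbers for stronger inhibition), compound 2 (`N[C@H]1CC[C@H](Nc2c(C(=O)NCc3ccco3)nc(Br)c3cccnc23)CC1`) gives > 10000 nM, which is a limit and not a number. Compound 3 (`O=C(NCc1ccc(F)cc1)c1nc(Br)c2cccnc2c1NCCCNc1c(C(=O)NCc2ccc(F)cc2)nc(Br)c2cccnc12`) gives > 20000 nM, which is also a limit. Among the measured compounds shown here, compound 1 (`N[C@H]1CC[C@H](Nc2c(C(=O)NCc3ccc(F)cc3)nc(N3CCCCS3(=O)=O)c3cccnc23)CC1`) has a substituted benzyl on its amide and gives 5000 nM, the only true number here. Compound 4 (`CN(C)c1ccc(CNC(=O)c2nc(Br)c3cccnc3c2N[C@H]2CC[C@H](N)CC2)cc1`) differs from compound 2 in one place: 4-(dimethylamino)phenyl in place of furan-2-yl on a saturated chain carbon bound to an amide-type nitrogen. For the measured compounds named here, no measured pair isolates this change, so any forecast is loose. Compound 1, at 5000 nM, suggests that a benzyl amide can give a measurable effect, although compound 3 carries one too and gives no number. The expected step is an at least 1.6-fold lower number from compound 2 to compound 4 (0.22 log units; that floor lies within the scatter), a modest move towards stronger inhibition. For compound 4 the estimated value is 6000 nM, with an expected range of 1500 nM to 20000 nM.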

Compound 4, half-maximal inhibitory concentration: 4000 nM
Compound 4: middle estimate off by 1.5-fold (0.18 log units), on the high side; the range from low to high includes it.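

Placing 4-(dimethylamino)phenyl instead of furan-2-yl on this saturated chain carbon gives, in this assay, an at least 2.5-fold lower number from compound 2 to compound 4 (0.39 log units; beyond the scatter). Among the compounds shown here, this is the first change at this place that can be read as a single step, and it lies beyond the scatter. Compound 2 stands only at a limit, so the true size of the step stays open: the limit of > 10000 nM in this assay, at which 1 of the 4 values shown sits.

The compounds shown leave open whether the dimethylamino group or the six-membered ring carries this step. A plain phenyl in the same place would help separate the two.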